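Inverting one stereocentre in the series

A few compounds are considered here, and "the series" means these few. Any claim that something is new, unique, unknown or untested is made for them only; others in the source may bear on it.

- compound 1 `Nc1ncnc2c1nc(Sc1cc3c(cc1Br)OCCO3)n2CCC1CCN(C=O)CC1`: > 50%, a limit
- compound 2 `Nc1ncnc2c1nc(Sc1cc3c(cc1Br)OCCO3)n2CCC1CCN(C(=O)CO)CC1`: > 50%, a limit
- compound 3 `C[C@H](O)C(=O)N1CCC(CCn2c(Sc3cc4c(cc3Br)OCCO4)nc3c(N)ncnc32)CC1`: > 50%, a limit

All three compounds were measured in an in vivo ADME assay on the whole organism (strain Swiss) for pharmacokinetics, with Mus musculus as the target, read by LC-MS, in phosphate buffer, at a dose of 10 mg/kg by the oral route; a higher number here means that a larger share of the oral dose reaches the circulation, a lower number that a smaller share of the oral dose reaches the circulation. Compound 3 stands at > 50%, which is a limit and not a number. The series as a whole offers only (the limit of > 50% in this assay, at which 3 of the 3 values shown sit).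

Compound 4 `C[C@@H](O)C(=O)N1CCC(CCn2c(Sc3cc4c(cc3Br)OCCO4)nc3c(N)ncnc32)CC1` is the next compound to read, and it differs from compound 3 in one respect: the two compounds have the same atoms and bonds and differ only in configuration as drawn: 1 of 1 stereo elements differ; a stereocentre at a saturated chain carbon is drawn S in compound 3 and R in compound 4.

The measured steps that bear on this change are a step that the two limits leave unreadable from compound 2 to compound 3, a step that the two limits leave unreadable from compound 1 to compound 2 and a step that the two limits leave unreadable from compound 1 to compound 3. Within the data shown here, none of them gives a size, and no measured pair compares two configurations. No step beyond the scatter is therefore expected in this assay, and no direction can be given. The estimated step is a step that the limit leaves unreadable from compound 3 to compound 4. For compound 4 the estimated value is 65%, with an expected range from 45% to 85%.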

Compound 4, oral bioavailability: > 50%
Compound 4: a limit, no number; the forecaster's own chance of this, stated with the estimate: 65%; the middle value is on the limit's open side.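

No step from compound 1, compound 2 or compound 3 to compound 4 can be read in this assay: the limit of > 50% in this assay, at which 4 of the 4 values shown sit.

Left open is whether oral bioavailability differs at all between the S configuration of compound 3 and the R configuration of compound 4.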